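The source may report more compounds than this note shows. Statements on the series, on what has been measured and on what is new or still open speak of the compounds shown alone.

Series notes. The shared core is carried by compound 1 `O=S1(=O)N=C(OCc2ccccc2)c2ccccc2N1Cc1ccccc1`, compound 2 `O=C1c2ccccc2N(Cc2ccc(Cl)cc2)S(=O)(=O)N1Cc1ccccc1` and compound 3 `O=C1c2ccccc2N(Cc2ccccc2Cl)S(=O)(=O)N1Cc1ccccc1Cl`, which differ from one another only in their pendant groups. In a functional assay on HEL cells (Homo sapiens) for inhibition (a lower number here means that less compound is tolerated, a higher number that more compound is tolerated), compound 1 gives > 200000 nM, which is a limit of the assay rather than a number. In this assay compound 2 likewise reaches only a limit, > 200000 nM. In this assay compound 3 also stops at a limit, > 200000 nM. Among the compounds with values here, compound 3 therefore stands exactly where the other two stand: all three values sit at the same limit, as the limit of > 200000 nM in this assay, at which 3 of the 3 values shown sit, records, and no step between measured compounds can be read from them.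

The next compound is compound 4 `O=C1c2ccccc2N(Cc2ccccc2Cl)S(=O)(=O)N1Cc1ccccc1`. From compound 3 the change is hydrogen in place of chloro on an aromatic carbon, so the 2-chlorobenzyl becomes benzyl. Within the data shown here, with no measured step available anywhere, the expectation for a step that the limit leaves unreadable from compound 3 to compound 4 is no step beyond the scatter in either direction, because the limit of > 200000 nM in this assay, at which 3 of the 3 values shown sit, shows every value so far at the same limit. Compound 4 is accordingly expected to give about 250000 nM in this assay, within 100000 nM to 600000 nM, and most probably again only as a limit.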

Compound 4, half-maximal cytotoxic concentration: 88000 nM
The estimate for compound 4 lay 2.8-fold (0.45 log units) above the measured number; measured number below the stated range.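

Hydrogen in place of chloro on an aromatic carbon, turning 2-chlorobenzyl into benzyl, is the first change in the series that can be read as a step: in this assay it gives an at least 2.2-fold lower number from compound 3 to compound 4 (0.35 log units; beyond the scatter). The place of the chloro also matters for this pair, as 2-chlorophenyl in place of 4-chlorophenyl on a saturated chain carbon bound to a sulfonamide nitrogen in a ring gives an at least 2.2-fold lower number from compound 2 to compound 4 (0.35 log units; beyond the scatter). Each of these steps gives only a minimum size, since compound 2 and compound 3 both stop at a limit of the assay: the limit of > 200000 nM in this assay, at which 3 of the 4 values shown sit.

On these data alone, the steps among the compounds at the limit cannot be read, and how far compound 2 and compound 3 truly lie from compound 4 also stays unknown. Whether another group on this aromatic carbon, such as a methoxy, an amine or a carboxylic acid, would move the number in the same direction as the chloro changes here is left open by the compounds shown.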